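This account rests on a few compounds, and the source may have more. Where it says the series, first, only, none or still open, it means among the compounds named here.

Measured compounds in a physicochemical assay for solubility; on this read-out lower numbers stand for lower solubility and higher numbers for higher solubility:
- compound 1 `CNC(=O)c1cc(C(=O)NCCC2CCOCC2)cn(Cc2ccccc2)c1=O`: the reading >= 127 ug/mL is a limit of the assay, not a number.
- compound 2 `CNC(=O)c1cc(C(=O)NC2CC2)cn(Cc2cccc3[nH]ccc23)c1=O`: 78 ug/mL
- compound 3 `CNC(=O)c1cc(C(=O)NC(C)C)cn(Cc2ccccc2)c1=O`: the reading >= 136 ug/mL is likewise a limit.

Compound 2 is the only one of the three with an actual number in this assay; the other two readings are limits. Within the data shown here, the single change between measured compounds, a step that the two limits leave unreadable from compound 1 to compound 3, cannot be sized because the limit of >= 127 ug/mL in this assay, at which 1 of the 3 values shown sits, and the limit of >= 136 ug/mL in this assay, at which 1 of the 3 values shown sits, cap both of its ends.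

Compound 4 `CNC(=O)c1cc(C(=O)NC2CC2)cn(Cc2cccc3occc23)c1=O` differs from compound 2 by 1-benzofuran-4-yl in place of 1H-indol-4-yl on a saturated chain carbon bound to an aromatic nitrogen. Among the measured compounds shown here, no measured step involves this change, and no measured step touches the saturated chain carbon bound to the aromatic nitrogen at all; the one step between measured compounds sits on an amide-type nitrogen and is unreadable anyway. The expectation for compound 4 therefore rests only on the number that compound 2 gives, 78 ug/mL, with nothing in the series to push it in either direction. The expected step of a 1.3-fold lower number from compound 2 to compound 4 (0.11 log units; within the scatter) is set to stay within the usual scatter. As far as these compounds go, compound 4 is estimated at 60 ug/mL in this assay, with a range from 25 ug/mL to 140 ug/mL; the wide range reflects that the change is untested here.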

Compound 4, solubility: >= 110 ug/mL
Compound 4: a limit, no number; the forecaster's own chance of this, stated with the estimate: 10%; middle value at least 1.8-fold (0.26 log units) from the limit.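

Compound 4 gives >= 110 ug/mL in this assay, and this reading is a limit, not a number. Among these compounds, it provides the first readable step on the saturated chain carbon bound to an aromatic nitrogen: 1-benzofuran-4-yl in place of 1H-indol-4-yl gives an at least 1.4-fold higher number from compound 2 to compound 4 (0.14 log units; that floor lies within the scatter), so going from 1 hydrogen-bond donor on the leaving group to 0 on the entering group brings no lower number in this pair, although the floor of the step does not clear the scatter. The full size of the step cannot be read because its upper end stops at a limit: the limit of >= 110 ug/mL in this assay, at which 1 of the 4 values shown sits.

The compounds shown leave open how far compound 4 really lies from compound 2, and whether the step would hold with an amide-type nitrogen substituent other than the one these two compounds share. They also leave open how an amine or a carboxylic acid would read on the saturated chain carbon bound to an aromatic nitrogen, since only 1H-indol-4-yl and 1-benzofuran-4-yl can be compared there.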